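The compounds below may be only part of what the source reports. "The series", "measured", "known", "first", "only" and "open" are said of these compounds alone.

In a functional assay on PANC-1 cells (Homo sapiens) for cytotoxicity, read by WST assay, with a stated time of 24 h (a higher number here means a weaker inhibitor, a lower number a stronger inhibitor), two related compounds have been tested so far. Compound 1 `O=C(CCCCCCCc1ccccc1)N1CCCCC1` gives > 100000 nM, which is a limit of the assay and not a number. Compound 2 `O=C(CCCCCCCCc1cccc(Cl)c1)N1CCCCC1` gives > 100000 nM, which is also a limit and not a number. Compound 2 therefore stands at the limit of > 100000 nM in this assay, at which 2 of the 2 values shown sit, so no true half-maximal inhibitory concentration is known for it.

Compound 3 `O=C(CCCCCCCCC1CCCCC1)N1CCCCC1` differs from compound 2 in one place: cyclohexyl in place of 3-chlorophenyl on a saturated chain carbon, eight bonds along the chain from a carbonyl carbon. In words, this puts cyclohexyl in place of 3-chlorophenyl on a saturated chain carbon, eight bonds along the chain from a carbonyl carbon. For the measured compounds named here, no measured pair shows what such a swap does, so no step beyond the scatter is expected in this assay, and neither direction is favoured. This expectation rests on compound 2, whose reading is the limit > 100000 nM. As a number, the expected size is a number no higher from compound 2 to compound 3 (the limit leaves the size open). For compound 3 the estimated value is 100000 nM, with an expected range from 40000 nM to 200000 nM.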

Compound 3, half-maximal inhibitory concentration: > 100000 nM
Compound 3 was reported as a limit; the forecaster's own chance of this, stated with the estimate: 80%; the middle value sits exactly at the limit.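

For the compounds shown here, compound 3 is also reported only as a limit, so no step to it from compound 1 or compound 2 can be read: the limit of > 100000 nM in this assay, at which 3 of the 3 values shown sit.

The compounds shown leave open the true half-maximal inhibitory concentration of each one in this assay and whether cyclohexyl in place of 3-chlorophenyl changes it at all.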